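Swapping Chloro for Cyano on the Benzyl Ring

This account rests on a few compounds, and the source may have more. Where it says the series, first, only, none or still open, it means among the compounds named here.

Measured so far in an assay on Sf21 cells for inhibition of ubiquitin carboxyl-terminal hydrolase 7 (Homo sapiens), read by spectrophotometry, with stated times of 30 min and 2 h; a lower number here means a stronger inhibitor, a higher number a weaker inhibitor:
- compound 3 `O=c1c2cnn(-c3ccc(F)cc3)c2ncn1CC1(O)CCN(Cc2ccccc2Cl)CC1` gives 3400 nM
- compound 2 `O=c1c2cnn(-c3ccc(F)cc3)c2ncn1CC1(O)CCN(Cc2ccccc2F)CC1` gives 9800 nM
- compound 1 `O=c1c2cnn(-c3ccc(F)cc3)c2ncn1CC1(O)CCN(Cc2cccnc2)CC1` has "not determined" (no result reported)

For the measured compounds named here, compound 3 holds the lowest number of the two reported in this assay; the one measured step, a 2.9-fold lower number from compound 2 to compound 3 (0.46 log units; beyond the scatter), is modest but beyond the scatter. Compound 4 `N#Cc1ccccc1CN1CCC(O)(Cn2cnc3c(cnn3-c3ccc(F)cc3)c2=O)CC1` changes compound 3 by cyano in place of chloro on an aromatic carbon. Going by the values given here, no measured pair shows a cyano group entering, so the fluoro-to-chloro step cannot be carried over directly; it only shows that this position tolerates a different small substituent. The expected change in this assay is therefore none beyond the scatter, a 1.2-fold higher number from compound 3 to compound 4 (0.07 log units; within the scatter), and compound 4 is estimated at 4000 nM, within 1500 nM to 12000 nM.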

Compound 4, half-maximal inhibitory concentration: 8100 nM
Estimate against measurement, compound 4: 2.0-fold (0.31 log units) below; low and high end bracket the measured number.
By their numbers in this assay, from the lowest: compound 3; then compounds 4 and 2 (each within the scatter of the next).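

In this assay, cyano in place of chloro gives a 2.4-fold higher number from compound 3 to compound 4 (0.38 log units; beyond the scatter), so a change at this place on the benzyl ring can also raise the number. Cyano in place of fluoro gives a 1.2-fold lower number from compound 2 to compound 4 (0.08 log units; within the scatter), which leaves these two groups indistinguishable here, while chloro alone stands apart among the three. No measured evidence bears on why this is so.

From the compounds shown here alone, it remains open whether a methyl or methoxy group at this place would match chloro or give a lower number. Going by these compounds, whether an amine or a carboxylic acid would be tolerated there also remains unknown.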